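Bromo for methyl on the phenyl ring of compound 2

The compounds below may be only part of what the source reports. "The series", "measured", "known", "first", "only" and "open" are said of these compounds alone.

Measured so far in an assay on CHO cells for displacement of a labelled ligand from adenosine receptor A3 (Homo sapiens), read by scintillation counting, with a stated time of 45 min, tested at 1 uM, in the presence of a further agent that is not named here; on this read-out lower numbers stand for less inhibition and higher numbers for more inhibition at the one concentration tested (going by the name of the read-out):
compound 1, `CCCn1c(=O)[nH]c2nc(-c3ccc(S(=O)(=O)N4CCN(Cc5cccc(C)c5)CC4)cc3)[nH]c2c1=O`: 17%
compound 2, `CCCn1c(=O)[nH]c2nc(-c3ccc(S(=O)(=O)N4CCN(c5ccccc5C)CC4)cc3)[nH]c2c1=O`: 25%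
compound 3, `CCCn1c(=O)[nH]c2nc(-c3ccc(S(=O)(=O)N4CCN(Cc5cccc(Br)c5)CC4)cc3)[nH]c2c1=O`: 23%

Compound 2 carries the highest of the three numbers, yet the step of a number 8 percentage points higher from compound 1 to compound 2 (within the scatter) and the step of a number 2 percentage points lower from compound 2 to compound 3 (within the scatter) both lie within the scatter, so the three compounds cannot be told apart on this read-out. Compound 4, `CCCn1c(=O)[nH]c2nc(-c3ccc(S(=O)(=O)N4CCN(c5ccccc5Br)CC4)cc3)[nH]c2c1=O`, is compound 2 with the change (bromo in place of methyl on an aromatic carbon); read one bond further out, 2-methylphenyl becomes 2-bromophenyl. Going by the values given here, one measured step bears directly on this: the same swap of bromo for methyl on an aromatic carbon, on the benzyl ring, gave a number 6 percentage points higher from compound 1 to compound 3 (within the scatter), within the scatter. The step of a number 8 percentage points higher from compound 1 to compound 2 (within the scatter) is the only other point of reference and is also within the scatter. The expectation for compound 4 is therefore a step of a number 2 percentage points higher from compound 2 to compound 4 (within the scatter), no larger than the scatter and of no settled direction. Compound 4 is estimated at 27% in this assay, in the range 14% to 40%.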

Compound 4, a percentage reported as inhibition, at one concentration (the size of the read-out at that concentration, not a potency): 20%
For compound 4 the middle estimate is 7 percentage points above the measured one; the measured number falls inside the stated range.
By their numbers in this assay, from the lowest: compounds 1, 4, 3 and 2 (each within the scatter of the next).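

In this assay, bromo in place of methyl on an aromatic carbon ortho to a large group gives a number 5 percentage points lower from compound 2 to compound 4 (within the scatter), so this change can now be read on the phenyl compounds as well as on the benzyl compounds. The two readings cannot be told apart, and no direction can be assigned to the change: the same change on two cores in this assay, a number 6 percentage points higher (within the scatter) from compound 1 to compound 3 and a number 5 percentage points lower (within the scatter) from compound 2 to compound 4, 11 percentage points apart, within the scatter of two such steps

Exchanging the whole group on the ring nitrogen gives the same picture, with a number 3 percentage points lower from compound 3 to compound 4 (within the scatter) and a number 3 percentage points higher from compound 1 to compound 4 (within the scatter), so the 2-bromophenyl group is not separated from either benzyl group on this read-out.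

From the compounds shown here alone, it remains open whether any other group at this position, such as methoxy, a nitrile or an amine, would give a step beyond the scatter. Readings at a single concentration also leave the potency of all four compounds open.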